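Swapping the Aryl Ring on the Carbonyl of Compound 1

A few compounds are considered here, and "the series" means these few. Any claim that something is new, unique, unknown or untested is made for them only; others in the source may bear on it.

Compound 1 `COc1ccc(/C=C/c2cc(OC)cc(OC)c2/C=C/C(=O)c2ccc(Cl)c(Cl)c2)cc1` was tested in a functional assay on B16-F10 cells (Mus musculus) for antiproliferative activity, read by MTT assay, with a stated time of 48 h (on this read-out lower numbers stand for stronger inhibition and higher numbers for weaker inhibition), and gave 7.5 ug/mL. Going by the values given here, only one other compound has a number here: compound 2 `CCCC(C)Oc1ccc(C(=O)/C=C/c2c(/C=C/c3ccc(OC)cc3)cc(OC)cc2OC)cc1`, which gives 6.7 ug/mL in this assay. Compound 1 is therefore not set apart from its neighbour; the step of a 1.1-fold lower number from compound 1 to compound 2 (0.05 log units; within the scatter) leaves the two compounds alongside each other.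

Compound 3 `COc1ccc(/C=C/c2cc(OC)cc(OC)c2/C=C/C(=O)c2ccc(C)cc2C)cc1` has not yet been measured. It differs from compound 1 in one place: 2,4-dimethylphenyl in place of 3,4-dichlorophenyl on a carbonyl carbon. Among the compounds with values here, the one measured step that bears on this change is a 1.1-fold lower number from compound 1 to compound 2 (0.05 log units; within the scatter), which also exchanged the aromatic ring on the carbonyl carbon and produced no shift beyond the scatter. Because the step of a 1.1-fold lower number from compound 1 to compound 2 (0.05 log units; within the scatter) left the number essentially unchanged, a step of similar size is expected in this assay for the present change, meaning none beyond the scatter, a 1.1-fold higher number from compound 1 to compound 3 (0.03 log units; within the scatter). Compound 3 is therefore estimated to give 8 ug/mL, within the range 4 ug/mL to 16 ug/mL.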

Compound 3, half-maximal inhibitory concentration: 4 ug/mL
Estimate against measurement, compound 3: 2.0-fold (0.30 log units) above; the range from low to high includes it.
By their numbers in this assay, from the lowest: compounds 3, 2 and 1 (each within the scatter of the next).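

In this assay, placing 2,4-dimethylphenyl on the carbonyl carbon gives both a 1.9-fold lower number from compound 1 to compound 3 (0.27 log units; within the scatter) and a 1.7-fold lower number from compound 2 to compound 3 (0.22 log units; within the scatter) with no step beyond the usual scatter. Three different aromatic rings now stand at this place with all three compounds within the scatter of one another, so among these compounds neither the chlorine atoms of compound 1 nor the 1-methylbutoxy chain of compound 2 is needed for a number of this size. Nothing measured here offers an explanation for why these rings read alike.

As far as these compounds go, all three rings are made of carbon only, so it stays open whether a pyridine ring, or a ring bearing an amine or a carboxylic acid, would also stay within the scatter. From the compounds shown here alone, whether the same holds on a different core also remains open.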